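Two Limits and a Shortened Hydrazide Side Chain

The source may report more compounds than this note shows. Statements on the series, on what has been measured and on what is new or still open speak of the compounds shown alone.

- compound 1 `Cc1cc(C)cc(S(=O)(=O)c2c(C(=O)NCC(=O)NN)[nH]c3ccc(Cl)cc23)c1`: > 100 uM
- compound 2 `O=C(NN1CCOC1=O)c1[nH]c2ccc(Cl)cc2c1S(=O)(=O)c1ccccc1`: > 100 uM

In a functional assay on C8166 cells (Homo sapiens) for antiproliferative activity, read by MTT assay (a lower number here means that less compound is tolerated, a higher number that more compound is tolerated), compound 1 gives > 100 uM, which is a limit of the assay and not a number. Compound 2 gives > 100 uM, again a limit. Both compounds therefore stand at the limit of > 100 uM in this assay, at which 2 of the 2 values shown sit, and no exact value is known for either.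

Compound 3 `CNNC(=O)c1[nH]c2ccc(Cl)cc2c1S(=O)(=O)c1cc(C)cc(C)c1` has not yet been measured. It keeps the core of compound 1 but carries methylamino in place of (aminocarbamoyl)methyl on an amide-type nitrogen.

Among the compounds with values here, no measured pair shows what such a change does. With compound 1 sitting at the limit of > 100 uM in this assay, at which 2 of the 2 values shown sit, the expectation in this assay is no step beyond the scatter, in either direction. The estimated step of a number no higher from compound 1 to compound 3 (the limit leaves the size open) is therefore small. For compound 3 the estimated value is 100 uM, with an expected range of 40 uM to 200 uM.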

Compound 3, half-maximal toxic concentration: > 100 uM
Compound 3: no number, only a limit (the forecaster's own chance of this, stated with the estimate: 60%); the middle value sits exactly at the limit.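

In this assay compound 3 gives only a limit, as compound 1 does, so no step can be read between compound 1 and compound 3: the limit of > 100 uM in this assay, at which 3 of the 3 values shown sit. What swapping (aminocarbamoyl)methyl for methylamino on the amide-type nitrogen does to tolerated concentration stays open, and none of the compounds shown has an exact value.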